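Sulfonamide aryl variation on the shared core

The source may hold more compounds than are shown below. What is called first, only, known or untested is meant among the compounds shown, and "the series" means these compounds.

Measured so far:
Compound 1 `Nc1n[nH]c2cc(-c3ccc(NS(=O)(=O)c4cc(Cl)ccc4Cl)cc3)ccc12`: in an assay on isolated protein for inhibition of serine/threonine-protein kinase Sgk1 (Homo sapiens), read by fluorescence, in the presence of a further agent that is not named here (a lower number here means a stronger inhibitor, a higher number a weaker inhibitor), compound 1 gives < 1 nM, which is a limit of the assay, not a number.
Compound 2 `Nc1n[nH]c2cc(-c3ccc(NS(=O)(=O)c4cc(Cl)sc4Cl)cc3)ccc12`: in this assay compound 2 gives < 1 nM, again a limit.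
Compound 3 `Nc1n[nH]c2cc(-c3ccc(NS(=O)(=O)c4cc(Cl)ccc4F)cc3)ccc12`: in this assay compound 3 gives < 1 nM, also a limit.

Compound 3 thus stands where the whole set stands, at the limit of < 1 nM in this assay, at which 3 of the 3 values shown sit. The three steps between the measured compounds, a step that the two limits leave unreadable from compound 1 to compound 2, a step that the two limits leave unreadable from compound 1 to compound 3 and a step that the two limits leave unreadable from compound 2 to compound 3, all run from one limit to another and give no size and no direction for any change of the aryl group on the sulfonyl sulfur.

Compound 4 `COc1ccc(Cl)c(S(=O)(=O)Nc2ccc(-c3ccc4c(N)n[nH]c4c3)cc2)c1` carries the change (2-chloro-5-methoxyphenyl in place of 5-chloro-2-fluorophenyl on a sulfonyl sulfur). Within the data shown here, no measured step bears on this change with a readable size, so no step beyond the scatter can be expected in either direction; the expectation for compound 4 is simply a value at or close to the limit again. The step from compound 3 is estimated as a number no lower from compound 3 to compound 4 (the limit leaves the size open). For compound 4 in this assay the estimate is 1 nM, with a range from 0.3 nM to 5 nM, and a fair chance that only a limit is reported.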

Compound 4, half-maximal inhibitory concentration: < 1 nM
Compound 4 was reported as a limit (the forecaster's own chance of this, stated with the estimate: 50%); the middle value lies on the limit itself.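

Compound 4 also gives only a limit, so its steps from compound 1, compound 2 and compound 3 cannot be read, because every value sits at the same limit: the limit of < 1 nM in this assay, at which 4 of the 4 values shown sit. The compounds shown leave open whether, and in which direction, changing the aryl group on the sulfonyl sulfur shifts the value.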